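Trading the Cyclic Amine of Compound 3 for an Open Chain

The compounds below may be only part of what the source reports. "The series", "measured", "known", "first", "only" and "open" are said of these compounds alone.

Compound 3 `Clc1cccc(-c2c[nH]c3ncnc(N4CCCCC4)c23)c1` stands lowest of the three compounds measured in an assay for inhibition of serine/threonine-protein kinase 4 (Homo sapiens), read by luminescence and ADP-Glo, in the presence of a further agent that is not named here; a higher number here means a weaker inhibitor, a lower number a stronger inhibitor; compound 3 gives 48 nM. Its nearest neighbour is compound 2 `CC1(N)CCN(c2ncnc3[nH]cc(-c4cccc(Cl)c4)c23)CC1`, which in this assay gives 163 nM, and the furthest is compound 1 `CCCN(C)c1ncnc2[nH]cc(-c3cccc(Cl)c3)c12`, which in this assay gives 208 nM. Both separations lie beyond the scatter: a 3.4-fold lower number from compound 2 to compound 3 (0.53 log units; beyond the scatter) and a 4.3-fold lower number from compound 1 to compound 3 (0.64 log units; beyond the scatter). Between compound 1 and compound 2 there is only a 1.3-fold lower number from compound 1 to compound 2 (0.11 log units; within the scatter).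

Compound 4 `CC(CO)CN(C)c1ncnc2[nH]cc(-c3cccc(Cl)c3)c12` takes compound 3 as its starting point, with the change (a group of 7 heavy atoms (5 carbon, 1 nitrogen, 1 oxygen; no ring) in place of a group of 6 heavy atoms (5 carbon, 1 nitrogen; one six-membered non-aromatic ring with 1 hetero atom), on an aromatic carbon). Among the compounds with values here, two measured steps bear on it. The step of a 4.3-fold lower number from compound 1 to compound 3 (0.64 log units; beyond the scatter) shows that closing the methyl(propyl)amino of compound 1 into the ring of compound 3 lowered the number modestly, and compound 4 undoes that closure while adding a hydroxymethyl branch to the chain. The step of a 3.4-fold lower number from compound 2 to compound 3 (0.53 log units; beyond the scatter) shows that carrying an amino and a methyl group on the ring of compound 3 went with a modestly higher number. Compound 4 is therefore expected to give a modestly higher number than compound 3, close to that of compound 1, as the step of a 3.8-fold higher number from compound 3 to compound 4 (0.57 log units; beyond the scatter). Compound 4 is estimated at 180 nM, within a range from 70 nM to 450 nM.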

Compound 4, half-maximal inhibitory concentration: 38 nM
Compound 4: the middle estimate sits 4.7-fold (0.68 log units) above what was measured, outside the stated range (below it).
By their numbers in this assay, from the lowest: compounds 4 and 3 (each within the scatter of the next); then compounds 2 and 1 (each within the scatter of the next).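

In this assay the open chain of compound 4 matches the piperidin-1-yl ring of compound 3 at this position on the aromatic carbon opposite the ring nitrogen, with a 1.3-fold lower number from compound 3 to compound 4 (0.10 log units; within the scatter) as the step, so a closed ring is not required for a number in this range. The sharper reading comes from a 5.5-fold lower number from compound 1 to compound 4 (0.74 log units; beyond the scatter) as the step for a single change, hydroxymethyl in place of hydrogen on a saturated chain carbon, which shows that the open chain of compound 1 need not stay at its higher number once it carries this branch. The same chain also separates clearly from the substituted ring, with a 4.3-fold lower number from compound 2 to compound 4 (0.63 log units; beyond the scatter) as the step.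

No measurement offered here accounts for the effect of the hydroxymethyl branch.

The compounds shown leave open whether the gain follows the hydroxyl or the added branch itself, a question that a methyl, methoxymethyl or aminomethyl group on the same chain carbon would address. They also leave open whether a hydroxymethyl group on the piperidin-1-yl ring of compound 3 would lower the number as it does on the open chain.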